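Series notes: a 2-hydroxyphenyl variant of compound 3

A few compounds are considered here, and "the series" means these few. Any claim that something is new, unique, unknown or untested is made for them only; others in the source may bear on it.

Compound 3 `CS(=O)(=O)c1ccc2nc(-c3ccc(-c4ccc(F)cc4)cc3)[nH]c2c1` gives 25 nM in an assay on isolated protein for inhibition of acyl-CoA desaturase 1 (Rattus norvegicus) (on this read-out lower numbers stand for stronger inhibition and higher numbers for weaker inhibition), the second highest of the three numbers in hand. Among the compounds with values here, compound 2 `CS(=O)(=O)c1ccc2nc(-c3ccc(-c4ccccc4)cc3)[nH]c2c1` gives 20 nM in this assay, and compound 1 `CN(C)S(=O)(=O)c1ccc2nc(-c3ccc(-c4ccccc4F)cc3)[nH]c2c1` gives 528 nM, a far higher number than compound 3; compound 1 differs from compound 3 in two places, so no single step is defined for that pair. Compound 4 `CS(=O)(=O)c1ccc2nc(-c3ccc(-c4ccccc4O)cc3)[nH]c2c1` carries 2-hydroxyphenyl in place of 4-fluorophenyl on an aromatic carbon. Within the data shown here, the one measured step that bears on this change is a 1.3-fold higher number from compound 2 to compound 3 (0.10 log units; within the scatter); no measured step covers a hydroxyl group. The expected step of a 1.6-fold higher number from compound 3 to compound 4 (0.20 log units; within the scatter) is therefore small and uncertain in direction. For compound 4 the estimate in this assay is 40 nM, with a range from 12 nM to 130 nM.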

Compound 4, half-maximal inhibitory concentration: 336 nM
Beside the measured number, compound 4's estimate is 8.4-fold (0.92 log units) below it; measured number outside the range, above it.
By their numbers in this assay, from the lowest: compounds 2 and 3 (each within the scatter of the next); then compounds 4 and 1 (each within the scatter of the next).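

In this assay, substitution on this phenyl group is not always neutral: hydroxy in place of hydrogen gives a 17-fold higher number from compound 2 to compound 4 (1.23 log units; beyond the scatter) in contrast to the fluoro step, which stays within the scatter. The direct exchange gives a 13-fold higher number from compound 3 to compound 4 (1.13 log units; beyond the scatter) and places compound 4 well apart from both close analogues. No available evidence bears on the reason for this rise.

The exchange alters both the group and its place on the ring, so the two contributions remain unseparated. A 4-hydroxyphenyl, 2-methoxyphenyl or 2-aminophenyl group on the core of compound 2 would address this.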